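Phenyl group change from compound 3 to compound 4

This account rests on a few compounds, and the source may have more. Where it says the series, first, only, none or still open, it means among the compounds named here.

In a functional assay on Jurkat cells (Homo sapiens) (on this read-out higher numbers stand for weaker inhibition and lower numbers for stronger inhibition), compound 3 `CC(C)[C@H](NC(=O)COc1cccc2ccccc12)C(=O)N[C@@H](CC(=O)O)C(=O)COc1c(F)ccc(F)c1F` gives the lowest number, 1200 nM, while compound 1 `CC(C)[C@H](NC(=O)COc1cccc2ccccc12)C(=O)N[C@@H](CC(=O)O)C(=O)COc1ccc(-c2ccccc2)cc1` gives 87900 nM. Compound 2 `CC(C)[C@H](NC(=O)COc1cccc2ccccc12)C(=O)N[C@@H](CC(=O)O)C(=O)COc1cccc(F)c1` reads > 100000 nM, which is a limit of the assay.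

Compound 4 `CC(C)[C@H](NC(=O)COc1cccc2ccccc12)C(=O)N[C@@H](CC(=O)O)C(=O)COc1c(F)c(F)c(F)c(F)c1F` carries 2,3,4,5,6-pentafluorophenyl in place of 2,3,6-trifluorophenyl, on an oxygen on a saturated carbon (2,3,4,5,6-pentafluorophenyl in place of 2,3,6-trifluorophenyl on an oxygen on a saturated carbon).

Among the compounds with values here, the closest precedent is the large step of an at least 83-fold lower number from compound 2 to compound 3 (1.92 log units; beyond the scatter), and a 73-fold lower number from compound 1 to compound 3 (1.86 log units; beyond the scatter) is also large. Both changes are wider than this one, which keeps the fluorinated phenyl. a 1.2-fold lower number from compound 3 to compound 4 (0.08 log units; within the scatter) is therefore the estimated step, expected to be small and, if anything, towards a lower number. Compound 4 is expected at 1000 nM, with an estimated range of 200 nM to 6000 nM.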

Compound 4, half-maximal inhibitory concentration: 3050 nM
For compound 4 the middle estimate is 3.1-fold (0.48 log units) below the measured one; the range from low to high includes it.
By their numbers in this assay, from the lowest: compound 3; then compound 4; then compound 1. At a limit, above all of these: compound 2.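

In this assay, going from 2,3,6-trifluorophenyl to 2,3,4,5,6-pentafluorophenyl does not extend the earlier gain, with a 2.5-fold higher number from compound 3 to compound 4 (0.41 log units; beyond the scatter), so the number does not fall steadily with the fluorine count across compounds 2, 3 and 4. The pentafluorophenyl group still keeps most of the advantage, with a 29-fold lower number from compound 1 to compound 4 (1.46 log units; beyond the scatter) and an at least 32-fold lower number from compound 2 to compound 4 (1.51 log units; beyond the scatter). The second of these steps rests on a limit for compound 2: the limit of > 100000 nM in this assay, at which 1 of the 4 values shown sits.

As far as these compounds go, it remains open which fluorines of the 2,3,6-trifluorophenyl group carry the gain. Also open, from the compounds shown here alone, is how a phenyl bearing a nitrile or trifluoromethyl would read here.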